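The compounds below may be only part of what the source reports. "The series", "measured", "known", "first", "only" and "open" are said of these compounds alone.

Measured compounds:
compound 1 `Cc1ccc(Nc2cncc(N3CC4CC(C3)N4)c2)cc1` with 0.148 nM
compound 2 `FC(F)(F)c1ccc(Nc2ccc(N3CC4CC(C3)N4)cn2)cc1` with 0.569 nM

In an assay on cell membranes for displacement of a labelled ligand from Neuronal acetylcholine receptor; alpha4/beta2 (Rattus norvegicus) (a higher number here means a weaker inhibitor, a lower number a stronger inhibitor), compound 1 gives the lower of the two numbers, and compound 2 stands above it by more than the usual scatter. Compound 3 `Clc1cccc(Nc2cncc(N3CC4CC(C3)N4)c2)c1` is not yet measured. It differs from compound 1 by 3-chlorophenyl in place of 4-methylphenyl on a nitrogen on an aromatic ring. For the measured compounds named here, no pair of measured compounds shows this change, so the expected step from compound 1 to compound 3 rests on the change alone; a small rise in the number, possibly within the scatter, is expected, a 2.0-fold higher number from compound 1 to compound 3 (0.31 log units; beyond the scatter). Compound 3 is therefore estimated at 0.3 nM, with a range from 0.08 nM to 1.2 nM.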

Compound 3, inhibition constant: 0.124 nM
The estimate for compound 3 lay 2.4-fold (0.38 log units) above the measured number, and the stated range covers the measured number.
By their numbers in this assay, from the lowest: compounds 3 and 1 (each within the scatter of the next); then compound 2.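

In this assay, putting 3-chlorophenyl in place of 4-methylphenyl on a nitrogen on an aromatic ring gives a 1.2-fold lower number from compound 1 to compound 3 (0.08 log units; within the scatter), so at this position the two groups read alike. The earlier compounds shown here gave no step at this place, and this one shows that the substituent and where it sits on the phenyl ring can both differ without moving the number beyond the scatter. Nothing in the data shown accounts for this. On these data alone, whether a phenyl ring carrying an amine or a carboxylic acid would read the same remains open. So does whether this change would behave alike on the core of compound 2.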